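Compound 4: the Benzyl Group Gives Way to Amino

The compounds below may be only part of what the source reports. "The series", "measured", "known", "first", "only" and "open" are said of these compounds alone.

These compounds were tested in an assay on HL-60 cells for agonist activity at N-formyl peptide receptor 3 (Homo sapiens), read by calcium flux; a lower number here means that less compound is needed, a higher number that more compound is needed for the effect. Compound 1 has the structure `Cc1cc(Cc2ccccc2)c(=O)n(CC(=O)Nc2ccc(Br)cc2)n1`. In this assay compound 1 gives > 50000 nM, which is a limit of the assay rather than a number. Compound 2, `Cc1cc(Cc2cccc(F)c2)c(=O)n(CC(=O)Nc2ccc(Br)cc2)n1`, gives > 50000 nM in this assay, again a limit. Compound 3, `Cc1cc(Cc2ccc(C#N)cc2)c(=O)n(CC(=O)Nc2ccc(Br)cc2)n1`, gives > 50000 nM in this assay, also a limit. The three steps that connect these compounds, a step that the two limits leave unreadable from compound 1 to compound 2, a step that the two limits leave unreadable from compound 1 to compound 3 and a step that the two limits leave unreadable from compound 2 to compound 3, have no readable size since (the limit of > 50000 nM in this assay, at which 3 of the 3 values shown sit). Compound 3 therefore stands at the limit on all the numbers shown, alongside the other two.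

Compound 4, `Cc1cc(N)c(=O)n(CC(=O)Nc2ccc(Br)cc2)n1`, differs from compound 3 in one change: amino in place of 4-cyanobenzyl on an aromatic carbon. All three measured steps bear on a change at this part of the shared core, yet none shows a size, so there is no basis to expect a step beyond the scatter in either direction. The estimated step from compound 3 to compound 4 is a number no higher from compound 3 to compound 4 (the limit leaves the size open), which is simply no readable change. Compound 4 is expected to give about 50000 nM in this assay, with a range from 10000 nM to 200000 nM, most probably reported once more only as a limit.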

Compound 4, half-maximal effective concentration: > 50000 nM
Compound 4 was reported as a limit (the forecaster's own chance of this, stated with the estimate: 80%); the middle value lies on the limit itself.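

For the compounds shown here, compound 4 also gives only a limit, so no step from compound 1, compound 2 or compound 3 to compound 4 can be read, because all four compounds share the same one: the limit of > 50000 nM in this assay, at which 4 of the 4 values shown sit. The compounds shown leave open how far each lies past this limit, and whether any group at this place on the shared core gives a readable value in this assay.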